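The source may hold more compounds than are shown below. What is called first, only, known or untested is meant among the compounds shown, and "the series" means these compounds.

Measured compounds in the series:

compound 1 `CC(C)c1cccc(C(C)C)c1OC(=O)NS(=O)(=O)Oc1ccccc1` – in an assay on liver for inhibition of sterol O-acyltransferase 1 (Rattus norvegicus), using microsomes (a higher number here means a weaker inhibitor, a lower number a stronger inhibitor), compound 1 gives > 50000 nM, which is a limit of the assay.
compound 2 `CC(C)c1cccc(C(C)C)c1OC(=O)NS(=O)(=O)Oc1ccc(F)cc1F` – in this assay compound 2 gives > 50000 nM, again a limit.
compound 3 `COc1cccc(OC)c1OS(=O)(=O)NC(=O)Oc1c(C(C)C)cccc1C(C)C` – in this assay compound 3 gives > 50000 nM, also a limit.

Compound 3 therefore stands at the upper edge of what the assay reports, together with the two other compounds; no number separates any of them. The steps between them, from compound 1 to compound 2 a step that the two limits leave unreadable from compound 1 to compound 2, from compound 1 to compound 3 a step that the two limits leave unreadable from compound 1 to compound 3 and from compound 2 to compound 3 a step that the two limits leave unreadable from compound 2 to compound 3, cannot be read in size, because all three values sit at the limit of > 50000 nM in this assay, at which 3 of the 3 values shown sit.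

Compound 4 `COc1cc(OC)c(OS(=O)(=O)NC(=O)Oc2c(C(C)C)cccc2C(C)C)c(OC)c1` is the next member. It differs from compound 3 in one place: methoxy in place of hydrogen on an aromatic carbon. The measured steps bearing on it are the three above, all unreadable; none of the aryl changes on the sulfamate oxygen has so far moved a value off the limit. The expectation for the step from compound 3 to compound 4 in this assay is therefore none beyond the scatter, and most likely a further limit. On that basis compound 4 is estimated at 60000 nM, within 20000 nM to 200000 nM, the step from compound 3 to compound 4 being expected as a step that the limit leaves unreadable from compound 3 to compound 4.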

Compound 4, half-maximal inhibitory concentration: > 50000 nM
Compound 4: only a limit was reported; the forecaster's own chance of this, stated with the estimate: 85%; the middle value is on the limit's open side.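

Compound 4 gives > 50000 nM in this assay, which is a limit of the assay. No new step can be read, as the change from compound 3 to compound 4 cannot be sized: the limit of > 50000 nM in this assay, at which 4 of the 4 values shown sit.

The compounds shown leave open whether any aryl group on the sulfamate oxygen of the shared core gives a measurable value in this assay.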